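Toward Compound 4: A Benzyl Group Replaces an Aryl Group

A few compounds are considered here, and "the series" means these few. Any claim that something is new, unique, unknown or untested is made for them only; others in the source may bear on it.

Compound 1 `CCCC[C@H](NC(=O)[C@H](CCCCN)NC(=O)[C@H](CCCNC(=N)N)NC(=O)c1ccc(/C=C2\SC(=O)N(c3ccc(C)cc3)C2=O)cc1)C(N)=O` is a short peptide-like molecule whose aromatic end carries a five-membered ring bearing a 4-methylphenyl group. In an ADME assay for permeability, using PAMPA (a higher number here means that the compound crosses the layer faster, a lower number that the compound crosses the layer more slowly), compound 1 gives 0.66 10^-6 cm/s. Two related compounds are recorded without a number. Compound 2 `CCCC[C@H](NC(=O)[C@H](CCCCN)NC(=O)[C@H](CCCNC(=N)N)NC(=O)c1ccc(/C=C/C(N)=O)cc1)C(N)=O` is reported in this assay as "impermeable" (no number reported), a result with no figure attached. Compound 3 `CCCC[C@H](NC(=O)[C@H](CCCN)NC(=O)[C@H](CCCNC(=N)N)NC(=O)c1ccc(/C=C2\SC(=O)N(Cc3ccccc3)C2=O)cc1)C(N)=O` is likewise reported in this assay as "impermeable" (no number reported), again without a figure. Among the measured compounds shown here, compound 1 therefore stands as the only entry with a measured number, and no step between two measured compounds is available to guide an expectation.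

Compound 4 `CCCC[C@H](NC(=O)[C@H](CCCCN)NC(=O)[C@H](CCCNC(=N)N)NC(=O)c1ccc(/C=C2\SC(=O)N(Cc3ccc(F)cc3)C2=O)cc1)C(N)=O` differs from compound 1 in a single place (4-fluorobenzyl in place of 4-methylphenyl on an amide-type nitrogen in a ring). For the measured compounds named here, with no measured step to draw on, the step of a 1.5-fold lower number from compound 1 to compound 4 (0.17 log units; within the scatter) is expected to be small, probably downward, and not clearly beyond the usual scatter. Compound 4 is estimated at 0.45 10^-6 cm/s, with a range from 0.15 10^-6 cm/s to 1.2 10^-6 cm/s.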

Compound 4, apparent permeability: 0.43 10^-6 cm/s
Estimate against measurement, compound 4: 1.0-fold (0.02 log units) above, within the range that was stated.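

In this assay, among the compounds shown here, the exchange of 4-methylphenyl for 4-fluorobenzyl on the amide-type nitrogen in a ring is a 1.5-fold lower number from compound 1 to compound 4 (0.19 log units; within the scatter) and gives the first step that can be read at this position. Within the scatter of this read-out, the two groups cannot be told apart, so an aromatic ring attached directly to this nitrogen and one attached through a single carbon link give numbers of the same standing here. No measurement shown gives a reason for this result.

The exchange alters the link and the ring substituent at once, so the compounds shown cannot assign any part of the step to either one. Also open, from the compounds shown here alone, is how the number would respond at this nitrogen to a longer chain ending in an amine or a carboxylic acid.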